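Ethyl Carbamate Variant of a Benzimidazole Carbamate Series

This account rests on a few compounds, and the source may have more. Where it says the series, first, only, none or still open, it means among the compounds named here.

Measured compounds:
compound 1 `CCNC(=O)c1ccc2[nH]c(NC(=O)OC)nc2c1`, 10000 nM
compound 2 `CCOC(=O)c1ccc2[nH]c(NC(=O)OC)nc2c1`, 2800 nM
compound 3 `COC(=O)Nc1nc2cc(C(=O)NC(C)C)ccc2[nH]1`, 2000 nM

All three were tested in a functional assay on L1210 cells (Mus musculus) for inhibition; on this read-out lower numbers stand for stronger inhibition and higher numbers for weaker inhibition. The cores of compound 1 and compound 2 differ by ethoxy in place of ethylamino on a carbonyl carbon, and this gave a 3.6-fold lower number from compound 1 to compound 2 (0.55 log units; beyond the scatter). Compound 3 differs from compound 1 by methyl in place of hydrogen on a saturated chain carbon bound to an amide-type nitrogen and a saturated chain carbon, which gave a 5.0-fold lower number from compound 1 to compound 3 (0.70 log units; beyond the scatter). Compound 2 and compound 3 lie close together, with a 1.4-fold lower number from compound 2 to compound 3 (0.15 log units; within the scatter).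

The unmeasured compound 4 `CCOC(=O)Nc1nc2cc(C(=O)OCC)ccc2[nH]1` differs from compound 2 by methyl in place of hydrogen on a saturated chain carbon bound to an oxygen next to a carbonyl group. For the measured compounds named here, this is the same kind of change as the one from compound 1 to compound 3, but not the same: there the methyl entered on a saturated chain carbon bound to an amide-type nitrogen and a saturated chain carbon, here it enters on a saturated chain carbon bound to an oxygen next to a carbonyl group. Going by the values given here, since no measured pair shows the change at this place, the earlier step is only a loose guide, and a smaller step is expected, around a 1.4-fold higher number from compound 2 to compound 4 (0.15 log units; within the scatter). Compound 4 is estimated at 4000 nM, with a range from 1200 nM to 15000 nM.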

Compound 4, half-maximal inhibitory concentration: 760 nM
Beside the measured number, compound 4's estimate is 5.3-fold (0.72 log units) above it; the whole stated range lies above it.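

Turning methoxycarbonyl into ethoxycarbonyl, the added methyl sitting on a saturated chain carbon bound to an oxygen next to a carbonyl group, gave a 3.7-fold lower number from compound 2 to compound 4 (0.57 log units; beyond the scatter) in this assay. Set beside the earlier methyl addition on a different core, this step runs in the same direction and is of similar size: the same change on two cores in this assay, a 5.0-fold lower number (0.70 log units; beyond the scatter) from compound 1 to compound 3 and a 3.7-fold lower number (0.57 log units; beyond the scatter) from compound 2 to compound 4, 1.4-fold (0.13 log units) apart, within the scatter of two such steps

This shows that adding the methyl lowered the number in both of these pairs, but two pairs are a small sample, and the methyl enters at a different kind of place in each, so the result does not show that the same step would appear on any other core in this series. The compounds shown leave open whether a longer chain, such as propoxycarbonyl in place of ethoxycarbonyl, would lower the number further. They also leave open what a carboxylic acid or a simple amine would give in place of the ethoxy on that carbonyl carbon.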